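Ethoxy for methoxy on a second quinazoline-type core

The compounds below may be only part of what the source reports. "The series", "measured", "known", "first", "only" and "open" are said of these compounds alone.

Compound 1 `COc1cc2ncnc(Nc3ccc(F)c(Cl)c3)c2cc1NC(=O)/C=C/CN(C)C1CC1` and compound 2 `CCOc1cc2ncnc(Nc3ccc(F)c(Cl)c3)c2cc1NC(=O)/C=C/CN(C)C1CC1` share one core and differ in a single place: methyl in place of hydrogen on a saturated chain carbon bound to an oxygen on an aromatic ring. In a functional assay on NCI-H1975 cells (Homo sapiens) for inhibition (on this read-out lower numbers stand for stronger inhibition of growth and higher numbers for weaker inhibition of growth), compound 1 gives 32.2 nM, and compound 2 gives 160 nM. For the measured compounds named here, the step between them, a 5.0-fold higher number from compound 1 to compound 2 (0.70 log units; beyond the scatter), is the only measured instance of this change among the compounds described here.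

Compound 3 `C#Cc1cccc(Nc2ncnc3cc(OC)c(NC(=O)/C=C/CNC4CC4)cc23)c1` is built on a different core; how the core of compound 3 differs from the core of compound 1 is not broken down here. In this assay compound 3 gives 18.9 nM, which sits within the scatter of compound 1 but well apart from compound 2.

Compound 4 `C#Cc1cccc(Nc2ncnc3cc(OCC)c(NC(=O)/C=C/CNC4CC4)cc23)c1` has not yet been measured. It differs from compound 3 in the same place as compound 2 differs from compound 1: methyl in place of hydrogen on a saturated chain carbon bound to an oxygen on an aromatic ring. The change is the same kind on both cores, though the surroundings of the core differ.

Going by the values given here, the expectation for compound 4 rests on the one measured instance of this change: because a 5.0-fold higher number from compound 1 to compound 2 (0.70 log units; beyond the scatter) was a modest weakening beyond the scatter, the step from compound 3 to compound 4 in this assay is estimated to be of similar size, namely a 5.0-fold higher number from compound 3 to compound 4 (0.70 log units; beyond the scatter). Among the compounds with values here, on that basis compound 4 is expected to give about 95 nM in this assay, with a plausible range from 40 nM to 220 nM, since only one prior example of this change on a different core is available.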

Compound 4, concentration for 50% growth inhibition: 16.5 nM
For compound 4 the middle estimate is 5.8-fold (0.76 log units) above the measured one, outside the stated range (below it).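

In this assay, methoxy to ethoxy on the core of compound 3 gives a 1.1-fold lower number from compound 3 to compound 4 (0.06 log units; within the scatter), so on this core the change leaves the read-out within the scatter. Set beside the earlier step, the same change does not carry over in size from one core to the other: the same change on two cores in this assay, a 5.0-fold higher number (0.70 log units; beyond the scatter) from compound 1 to compound 2 and a 1.1-fold lower number (0.06 log units; within the scatter) from compound 3 to compound 4, 5.7-fold (0.76 log units) apart, beyond the scatter of two such steps. For the compounds shown here, this shows that the step seen on the core of compound 1 cannot simply be transferred to the core of compound 3, but with only one pair on each core it does not show which difference between the two cores goes with the gap, or whether either step is typical of its own core.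

The compounds shown leave open how a longer chain on the oxygen, such as propoxy, or a larger group such as cyclopropylmethoxy, would read on either core. Going by these compounds alone, they also leave open how methoxy to ethoxy would read on a third core, for instance one carrying a morpholine, and so whether the step seen with compound 1 and compound 2 or the one seen with compound 3 and compound 4 is the more usual.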